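The source may report more compounds than this note shows. Statements on the series, on what has been measured and on what is new or still open speak of the compounds shown alone.

Measured compounds:
compound 1 `COc1ccc(-c2csc(N/N=C/c3ccc(Cl)cc3Cl)n2)cc1` — 69.5%
compound 2 `Clc1ccc(-c2csc(N/N=C/c3ccc(Cl)cc3Cl)n2)cc1` — 85.9%

In a functional assay, read by spectrophotometry, with a stated time of 15 min, tested at 40 ug/mL (a higher number here means a stronger effect of the compound at the concentration tested, a lower number a weaker effect), compound 2 gives the higher of the two numbers shown, compound 1 the lower; the one measured step, a number 16.4 percentage points higher from compound 1 to compound 2 (beyond the scatter), lies beyond the scatter and is modest in size.

Compound 3 `Clc1ccc(/C=N/Nc2nc(-c3ccccc3)cs2)c(Cl)c1` is the next member. Its difference from compound 2 is hydrogen in place of chloro on an aromatic carbon. The change sits at the same aromatic carbon where the measured step put chloro in place of methoxy, so that step is the only one that bears on it: it shows that the chloro at this position is worth a modest gain over methoxy. Taking the chloro away altogether, leaving hydrogen, is therefore expected to cost something in this assay, most likely a modest decrease rather than none beyond the scatter, though a hydrogen is not a methoxy and the loss could be smaller. For compound 3 the estimated value in this assay is 72% (range 56% to 88%), an expected step of a number 13.9 percentage points lower from compound 2 to compound 3 (beyond the scatter).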

Compound 3, a percentage reported as inhibition, at one concentration (the size of the read-out at that concentration, not a potency): 90.2%
Beside the measured number, compound 3's estimate is 18.2 percentage points below it; the whole stated range lies below it.
By their numbers in this assay, from the lowest: compound 1; then compounds 2 and 3 (each within the scatter of the next).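

In this assay, going from the 4-chlorophenyl to the phenyl group gives a number 4.3 percentage points higher from compound 2 to compound 3 (within the scatter) and so does not separate chloro from hydrogen at this aromatic carbon. The gain that chloro showed over methoxy therefore does not require chloro, since hydrogen in place of methoxy gives a number 20.7 percentage points higher from compound 1 to compound 3 (beyond the scatter) as well. Among these three compounds, methoxy is the substituent that stands apart, and nothing available on these compounds accounts for this.

On these data alone, it remains open whether the lower number belongs to methoxy alone or would also appear with another group at this carbon, such as an amine, a carboxylic acid or a longer alkoxy chain. Also open, as far as these compounds go, is whether the same reading would hold if the two chloro groups on the other aromatic ring were changed.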